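Notes on the amide variation in the writhing series

This account rests on a few compounds, and the source may have more. Where it says the series, first, only, none or still open, it means among the compounds named here.

Compound 1 `COc1cc2c(cc1OC)C(CC(=O)O)CC2` carries a hydroxy on a carbonyl carbon of the shared core; in a functional assay on the whole organism (strain Swiss Albino) for inhibition, with Mus musculus as the target, in the writhing test, with a stated time of 1 h, at a dose of 100 mg/kg by the oral route (on this read-out lower numbers stand for less inhibition and higher numbers for more inhibition at the one dose given (going by the name of the read-out)), compound 1 gives 44%. Compound 2 `COc1cc2c(cc1OC)C(CC(=O)Nc1ccc(Cl)cc1)CC2` carries (4-chlorophenyl)amino in place of that hydroxy, and in this assay compound 2 gives 73.6%. For the measured compounds named here, the only measured step, a number 29.6 percentage points higher from compound 1 to compound 2 (beyond the scatter), lies beyond the scatter, so compound 2 stands highest of the two numbers measured so far. Compound 3 `COc1cc2c(cc1OC)C(CC(=O)Nc1ccccc1C)CC2` is the next member: 2-methylphenyl in place of 4-chlorophenyl on an amide-type nitrogen. Going by the values given here, no measured step exchanges one aryl group on the amide-type nitrogen for another; the single step from compound 1 to compound 2 concerns the amide itself rather than the group on its nitrogen, so it shows only that an arylamide can sit well above the acid. Without a comparable step there is no ground for a direction, and the expected change a number 8.6 percentage points lower from compound 2 to compound 3 (within the scatter) is taken as none beyond the scatter. Compound 3 is accordingly estimated at 65%, with a range from 45% to 85%.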

Compound 3, a percentage reported as inhibition, in the whole organism at one dose (the size of the read-out at that dose, not a potency): 30%
Compound 3: the middle estimate sits 35 percentage points above what was measured, outside the stated range (below it).
By their numbers in this assay, from the lowest: compound 3; then compound 1; then compound 2.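

In this assay, for the compounds shown here, the aryl group on the amide-type nitrogen proves decisive, since 2-methylphenyl in place of 4-chlorophenyl gives a large step, a number 43.6 percentage points lower from compound 2 to compound 3 (beyond the scatter), which the earlier compounds could not show. An arylamide therefore does not sit above the acid as such: (2-methylphenyl)amino in place of hydroxy on a carbonyl carbon gives a number 14 percentage points lower from compound 1 to compound 3 (beyond the scatter), so the rise seen with compound 2 is not general, and compound 3 goes against any rule that amide formation raises the read-out. The data at hand offer nothing that accounts for this reversal.

The exchange from compound 2 to compound 3 alters both the substituent, chlorine for methyl, and the number in the group's name, so the compounds shown cannot tell which of the two changes carries the step. From the compounds shown here alone, how plain phenyl or a benzylamino group on the same carbonyl carbon would stand against compound 1 and compound 2 remains open, as does whether these differences at a single dose would hold at other doses.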